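The source may hold more compounds than are shown below. What is called first, only, known or untested is meant among the compounds shown, and "the series" means these compounds.

Values in a functional assay on MCF7 cells (Homo sapiens) for cytotoxicity, read by sulforhodamine B assay, with a stated time of 72 h; a lower number here means a stronger inhibitor, a higher number a weaker inhibitor:
- compound 1 `O=C(Nc1ccc(Cl)c(C(F)(F)F)c1)c1ccc(Nc2ncnc3c2cnn3-c2ccccc2)cc1`: 75900 nM
- compound 2 `O=C(NC1CCCCC1)c1ccc(Nc2ncnc3c2cnn3-c2ccc(Cl)cc2)cc1`: > 100000 nM (a limit)
- compound 3 `O=C(Nc1ccccc1Cl)c1ccc(Nc2ncnc3c2cnn3-c2ccc(Cl)cc2)cc1`: > 100000 nM (a limit)
- compound 4 `O=C(Nc1ccc(Cl)c(C(F)(F)F)c1)c1ccc(Nc2ncnc3c2cnn3-c2ccc(Cl)cc2)cc1`: not yet measured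

Compound 3 stands only at a limit, > 100000 nM. Across the series, the picture is the limit of > 100000 nM in this assay, at which 2 of the 3 values shown sit. The next change is 4-chloro-3-(trifluoromethyl)phenyl in place of 2-chlorophenyl on an amide-type nitrogen, with 4-chloro-3-(trifluoromethyl)phenyl in place of 2-chlorophenyl on an amide-type nitrogen. Within the data shown here, the only measured step, a step that the two limits leave unreadable from compound 2 to compound 3, offers no size to carry over. Among the measured compounds shown here, compound 1 carries the same 4-chloro-3-(trifluoromethyl)phenyl and gives 75900 nM, the only number so far. On that basis, a modest move toward stronger inhibition is expected in this assay, though another limit remains possible. The estimated change is an at least 1.6-fold lower number from compound 3 to compound 4 (0.22 log units; that floor lies within the scatter). For compound 4 the estimated value is 60000 nM, with an expected range of 15000 nM to 100000 nM.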

Compound 4, half-maximal inhibitory concentration: 4920 nM
The estimate for compound 4 lay 12-fold (1.09 log units) above the measured number; the measured number lies below the stated range.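

In this assay, 4-chloro-3-(trifluoromethyl)phenyl on the amide-type nitrogen gives the first readable separation from 2-chlorophenyl and cyclohexyl, with an at least 20-fold lower number from compound 3 to compound 4 (1.30 log units; beyond the scatter) and an at least 20-fold lower number from compound 2 to compound 4 (1.30 log units; beyond the scatter). Both sizes are floors, set by a limit of the assay: the limit of > 100000 nM in this assay, at which 2 of the 4 values shown sit.

The amide group alone does not set the value, as chloro in place of hydrogen on an aromatic carbon gives a 15-fold lower number from compound 1 to compound 4 (1.19 log units; beyond the scatter).

As far as these compounds go, how a pyridyl group or a longer alkyl chain on that amide-type nitrogen would read stays open. Also open, from the compounds shown here alone, is whether the chloro step holds with any group other than 4-chloro-3-(trifluoromethyl)phenyl.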